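The source may report more compounds than this note shows. Statements on the series, on what has been measured and on what is new or still open speak of the compounds shown alone.

Series notes. Of the compounds shown here, two have been measured in an assay for inhibition of Pro-cathepsin H (Homo sapiens), read by fluorescence, tested at 50 uM; on this read-out higher numbers stand for more inhibition at the one concentration tested (going by the name of the read-out) and lower numbers for less inhibition. Compound 1 `COC(=O)c1ccccc1Oc1nc(OC)nc(OC)n1` gives -5.34% there. Compound 2 `O=c1nc(SCc2ccccc2)nc(SCc2ccc(Cl)cc2)[nH]1` gives 6.91% in this assay, which is the higher of the two numbers; the gap to compound 1 lies beyond the usual scatter, so compound 2 stands above compound 1 on this read-out, though both numbers are small.

Compound 3 `O=c1nc(SCc2ccccc2)nc(SCC2CCCC2)[nH]1` has not been measured. It differs from compound 2 in one place: cyclopentyl in place of 4-chlorophenyl on a saturated chain carbon bound to a sulfur.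

For the measured compounds named here, no step between two measured compounds shares this change, so nothing in the measured pair tells how a cyclopentyl in place of a 4-chlorophenyl moves the read-out. With compound 2 at 6.91%, a step from compound 2 to compound 3 of roughly a number 3.9 percentage points lower from compound 2 to compound 3 (within the scatter) is expected, that is none beyond the scatter, leaning slightly downward. Compound 3 is therefore estimated at 3% in this assay, within a range from -12% to 18%.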

Compound 3, a percentage reported as inhibition, at one concentration (the size of the read-out at that concentration, not a potency): 10.6%
The estimate for compound 3 lay 7.6 percentage points below the measured number; measured number inside the range.
By their numbers in this assay, from the lowest: compound 1; then compounds 2 and 3 (each within the scatter of the next).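

Working notes on this position: in this assay, a number 3.7 percentage points higher from compound 2 to compound 3 (within the scatter), so the step from 4-chlorophenyl to cyclopentyl on a saturated chain carbon bound to a sulfur stays within the scatter. The six-membered aromatic ring with its chlorine and the five-membered non-aromatic carbon ring therefore cannot be told apart on this read-out at the one concentration tested. Nothing measured on these compounds speaks to why the two groups read alike.

On these data alone, it remains open whether an amine or a carboxylic acid at this place, or a longer chain in place of the cyclopentylmethyl, would give a step beyond the scatter. As far as these compounds go, it is also open whether any group at this place would lift the inhibition well clear of the small numbers seen so far.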